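A few compounds are considered here, and "the series" means these few. Any claim that something is new, unique, unknown or untested is made for them only; others in the source may bear on it.

Measured compounds: compound 1 `COc1ccccc1N1C(=O)CSC1c1cc(F)cc(C(=O)O)c1` gives > 1000 nM; compound 2 `O=C(NCCCCc1ccccc1)c1cccc(C2SCC(=O)N2c2cccc(F)c2)c1` gives 32.4 nM; compound 3 `CCOc1ccccc1N1C(=O)C(C)SC1c1cccc(C(=O)NCCCCc2ccccc2)c1` gives 71.6 nM.

In a functional assay on HOS-TE85 cells (Homo sapiens) for inhibition, read by CCK-8 assay, with a stated time of 72 h (a higher number here means a weaker inhibitor, a lower number a stronger inhibitor), compound 1 reaches only a limit of the assay, > 1000 nM, the line at which (the limit of > 1000 nM in this assay, at which 1 of the 3 values shown sits). Compound 2, which carries the (4-phenylbutyl)amino group on its carbonyl carbon, gives 32.4 nM in this assay. Compound 3, carrying the same group, gives 71.6 nM.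

Compound 4 `COc1ccccc1N1C(=O)CSC1c1cc(F)cc(C(=O)NCCCCc2ccccc2)c1` differs from compound 1 in one place: (4-phenylbutyl)amino in place of hydroxy on a carbonyl carbon. Among the measured compounds shown here, no measured pair shows this change directly. Since compound 2 sits at 32.4 nM and compound 3 at 71.6 nM, both carrying this group, compound 4 is expected to move well beyond the scatter toward stronger inhibition, by about an at least 16-fold lower number from compound 1 to compound 4 (1.22 log units; beyond the scatter). Compound 4 is estimated at 60 nM, between 20 nM and 200 nM.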

Compound 4, half-maximal inhibitory concentration: 40.9 nM
Estimate against measurement, compound 4: 1.5-fold (0.17 log units) above; the measured number falls inside the stated range.
By their numbers in this assay, from the lowest: compounds 2, 4 and 3 (each within the scatter of the next, the first and the last beyond it). At a limit, above all of these: compound 1.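

In this assay, putting (4-phenylbutyl)amino in place of hydroxy on a carbonyl carbon gives an at least 24-fold lower number from compound 1 to compound 4 (1.38 log units; beyond the scatter). Among the compounds shown here, this is the first pair that differs in one place only, so the change is now read directly on the core of compound 1 rather than inferred from compounds with other differences. The true size of the step remains unknown because compound 1 stands at a limit: the limit of > 1000 nM in this assay, at which 1 of the 4 values shown sits.

The compounds shown leave open whether a shorter chain, such as (2-phenylethyl)amino, or a plain butylamino group without the phenyl ring would give a similar number at this carbonyl carbon.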